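Adding a Hydroxy Group to Compound 2

This account rests on a few compounds, and the source may have more. Where it says the series, first, only, none or still open, it means among the compounds named here.

Compound 1 `COc1ccc2c(c1)/C(=C\c1c(Cl)[nH]c3ccc(N(C)C)cc13)C(=O)N2` gives 58900 nM
Compound 2 `COc1cc2c(/C=C3/C(=O)N(C)c4ccccc43)c[nH]c2cc1C` gives 93300 nM

In a functional assay on NSCLC cells (Homo sapiens) for inhibition, with a stated time of 48 h (a higher number here means that more compound is tolerated, a lower number that less compound is tolerated), compound 2 lies within the usual scatter of compound 1, so these two numbers set no ranking. Compound 3 `COc1cc2c(/C=C3/C(=O)N(C)c4ccc(O)cc43)c[nH]c2cc1C` is compound 2 with a single change (hydroxy in place of hydrogen on an aromatic carbon), hydroxy in place of hydrogen on an aromatic carbon. Within the data shown here, no measured pair shows the effect of this change, so the expectation is uncertain. The expected step of a 1.9-fold lower number from compound 2 to compound 3 (0.27 log units; within the scatter) is small, towards less compound tolerated, and may stay within the scatter. Compound 3 is estimated at 50000 nM (range 12000 nM to 150000 nM).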

Compound 3, concentration lethal to 50% of the cells: 91200 nM
For compound 3 the middle estimate is 1.8-fold (0.26 log units) below the measured one; the range from low to high includes it.
By their numbers in this assay, from the lowest: compounds 1, 3 and 2 (each within the scatter of the next).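

In this assay, hydroxy in place of hydrogen on an aromatic carbon gives a 1.0-fold lower number from compound 2 to compound 3 (0.01 log units; within the scatter). Among these compounds, this is the first measured pair for this change, and it shows that this place on the six-membered aromatic ring takes a hydroxy with no shift that can be told from the scatter. Nothing measured here accounts for this result.

From the compounds shown here alone, whether an amine or a carboxylic acid at the same place would also stay within the scatter remains open, and so does the effect of a longer chain there.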